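The compounds below may be only part of what the source reports. "The series", "measured", "known", "first", "only" and "open" are said of these compounds alone.

In a functional assay on A2780 cells (Homo sapiens) for antiproliferative activity (on this read-out higher numbers stand for weaker inhibition and lower numbers for stronger inhibition), compound 1 `Cc1ccc2c(c1C)CN(CCCN(C)C)CC2c1ccccc1` gives 3240 nM and compound 2 `Cc1ccc2c(c1C)CN(C(=O)N1CCCCC1)CC2c1ccccc1` gives 2830 nM as its reading. Compound 3 `CN(C)C(=O)N1Cc2ccccc2C(c2cccc(O)c2)C1` offers no starting number: its entry reads "not determined" (no result reported) and no position can be assigned to it. Compound 4 `CN(C)C(=O)N1Cc2cc(Br)ccc2C(c2cccc(O)c2)C1` differs from compound 3 by one change, bromo in place of hydrogen on an aromatic carbon on the shared core. Within the data shown here, the only measured step (a 1.1-fold lower number from compound 1 to compound 2 (0.06 log units; within the scatter)) exchanges a group on a ring nitrogen and involves no bromo, so it does not bear on this change. With no value for compound 3, no size or direction of step can be expected in this assay, and only the general level of the measured compounds remains as a guide. Compound 4 is estimated at 3500 nM (expected range 900 nM to 14000 nM).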

Compound 4, half-maximal inhibitory concentration: 879 nM
For compound 4 the middle estimate is 4.0-fold (0.60 log units) above the measured one; the whole stated range lies above it.
By their numbers in this assay, from the lowest: compound 4; then compounds 2 and 1 (each within the scatter of the next).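

Among these compounds, with no number for compound 3 in this assay, no step to compound 4 can be read. From the compounds shown here alone, the effect of bromo in place of hydrogen on the shared core stays open. No evidence at hand explains the reading of compound 4.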